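Compound 3 to compound 4: 4-chlorophenyl on the amide-type nitrogen

The source may hold more compounds than are shown below. What is called first, only, known or untested is meant among the compounds shown, and "the series" means these compounds.

- Compound 1 `COc1cc(NC(C)CCCNC(=O)NNC(=O)Nc2ccc(F)cc2)c2ncccc2c1`: >= 250000 nM (a limit)
- Compound 2 `COc1cc(NC(C)CCCNC(=O)Nc2cccc(O)c2)c2ncccc2c1`: 48000 nM
- Compound 3 `COc1cc(NC(C)CCCNC(=O)NNC(=O)Nc2cccc(F)c2)c2ncccc2c1`: > 250000 nM (a limit)

In a functional assay on HeLa cells (Homo sapiens) for inhibition, read by MTT assay, with a stated time of 72 h (a higher number here means a weaker inhibitor, a lower number a stronger inhibitor), compound 3 stands only at a limit (> 250000 nM). Compound 4 `COc1cc(NC(C)CCCNC(=O)Nc2ccc(Cl)cc2)c2ncccc2c1` differs from it as follows: 4-chlorophenyl in place of ((3-fluorophenyl)carbamoyl)amino on an amide-type nitrogen; in words, 4-chlorophenyl replaces ((3-fluorophenyl)carbamoyl)amino on an amide-type nitrogen. The closest measured change at this place is an at least 5.2-fold higher number from compound 2 to compound 3 (0.71 log units; beyond the scatter), beyond the scatter. It is matched by an at least 5.2-fold lower number from compound 1 to compound 2 (0.71 log units; beyond the scatter), also beyond the scatter. The remaining step, a step that the two limits leave unreadable from compound 1 to compound 3, gives no guidance. Compound 2 (48000 nM) is thus the reference for an aryl group on that nitrogen. Expected in this assay is an at least 5.5-fold lower number from compound 3 to compound 4 (0.74 log units; beyond the scatter), toward a lower number. The estimated value for compound 4 is 45000 nM (expected range 15000 nM to 130000 nM).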

Compound 4, half-maximal inhibitory concentration: 18000 nM
Compound 4: the middle estimate sits 2.5-fold (0.40 log units) above what was measured, and the stated range covers the measured number.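

In this assay, replacing either carbamoylamino group with 4-chlorophenyl directly on the amide-type nitrogen gives a readable gain: an at least 13-fold lower number from compound 3 to compound 4 (1.14 log units; beyond the scatter), and an at least 13-fold lower number from compound 1 to compound 4 (1.14 log units; beyond the scatter). The aryl group itself also matters, as two aryl groups at this place separate, with a 2.7-fold lower number from compound 2 to compound 4 (0.43 log units; beyond the scatter). The two larger steps start from limits for compound 1 and compound 3, so their full size stays unknown: the limit of > 250000 nM in this assay, at which 1 of the 4 values shown sits.

On these data alone, whether the chlorine carries the gain remains open. Unsubstituted phenyl, 4-fluorophenyl or 4-methylphenyl on the same nitrogen would test this.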